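The source may report more compounds than this note shows. Statements on the series, on what has been measured and on what is new or still open speak of the compounds shown alone.

Working notes on the series.

Two compounds of this set have been run in an ADME assay for permeability, using PAMPA, with a stated time of 30 min, at pH 7.4; on this read-out higher numbers stand for higher permeability and lower numbers for lower permeability. Compound 1 `COc1ccc(-c2ccc3c(NCCCNCc4cccc(OC)c4O)ccnc3c2)cc1` gives 237 10^-6 cm/s, and compound 2 `COc1cccc(CNCCCNc2ccnc3cc(Oc4cccc(N(C)C)c4)ccc23)c1O` gives 317 10^-6 cm/s. For the measured compounds named here, the single step between them, a 1.3-fold higher number from compound 1 to compound 2 (0.13 log units; within the scatter), does not separate the two numbers beyond the scatter, so compound 2 stands alongside compound 1 rather than apart from it; with only two measured compounds no spread of numbers has yet been seen.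

Compound 3 `COc1cccc(CNCCCNc2ccnc3cc(-c4ccccc4)ccc23)c1O` is the next member. The change from compound 2 is phenyl in place of 3-(dimethylamino)phenoxy on an aromatic carbon. Going by the values given here, the only measured step that bears on this position is a 1.3-fold higher number from compound 1 to compound 2 (0.13 log units; within the scatter), which exchanged one substituted aryl group for another at the same carbon and stayed within the scatter. Compound 1 already carries a 4-methoxyphenyl at this position, a closer relative of the phenyl entering in compound 3, and its value sits close to that of compound 2. On that basis no step beyond the scatter is expected in this assay for compound 3, in either direction, which amounts to an expected step of a 1.2-fold lower number from compound 2 to compound 3 (0.07 log units; within the scatter). Compound 3 is therefore estimated at 270 10^-6 cm/s, with an expected range from 130 10^-6 cm/s to 550 10^-6 cm/s.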

Compound 3, apparent permeability: 237 10^-6 cm/s
Compound 3: the middle estimate sits 1.1-fold (0.06 log units) above what was measured; the range from low to high includes it.
By their numbers in this assay, from the lowest: compounds 1, 3 and 2 (each within the scatter of the next).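

In this assay the step to phenyl reads a 1.3-fold lower number from compound 2 to compound 3 (0.13 log units; within the scatter), so a group of 6 heavy atoms with no hydrogen-bond acceptors stands at this aromatic carbon in place of 3-(dimethylamino)phenoxy, with its 10 heavy atoms and 2 hydrogen-bond acceptors, without a step beyond the scatter. For the compounds shown here, the pair of compounds 1 and 3 adds a first reading of hydrogen in place of methoxy on an aromatic carbon, with no change at the digits printed from compound 1 to compound 3 (within the scatter), so the methoxy group of the 4-methoxyphenyl shows no separable effect on this read-out either. All three compounds now lie within the scatter of their neighbours in the order of their numbers, and nothing on hand explains this flat picture.

As far as these compounds go, the three groups seen at this carbon all contain a six-membered aromatic ring of carbon only, so the reading for a carboxylic acid or a morpholine there remains open. Also open, from the compounds shown here alone, is whether a phenyl carrying a trifluoromethyl or a nitrile would stay within the scatter of these three compounds.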